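The source may report more compounds than this note shows. Statements on the series, on what has been measured and on what is new or still open speak of the compounds shown alone.

Compound 1 `Cc1[nH]c2ccccc2c1C(c1ccccc1)c1cc2ccccc2o1` and compound 2 `Cc1[nH]c2ccccc2c1C(c1ccccc1)c1cc2cc(Cl)ccc2o1` share one core and differ in a single spot: compound 2 carries a chloro group where compound 1 carries hydrogen, the change (chloro in place of hydrogen on an aromatic carbon). In a functional assay on SiHa cells (Homo sapiens) for cytotoxicity (on this read-out lower numbers stand for stronger inhibition and higher numbers for weaker inhibition), compound 1 gives 56500 nM, and compound 2 gives 47500 nM. The step of a 1.2-fold lower number from compound 1 to compound 2 (0.08 log units; within the scatter), so the two values cannot be told apart on this read-out.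

Compound 3 `Cc1c(C(c2ccccc2)c2cc3ccccc3o2)[nH]c2ccccc12` is made of the same atoms as compound 1, joined differently; the difference between the two cores is not broken down here. For compound 3 this assay reports only a limit, > 100000 nM.

Compound 4 `Cc1c(C(c2ccc(Cl)cc2)c2cc3ccccc3o2)[nH]c2ccccc12` stands to compound 3 much as compound 2 stands to compound 1: chloro in place of hydrogen on an aromatic carbon. The place is not the same, though. In compound 2 the chloro sits on an aromatic carbon of a six-membered aromatic ring of carbon only, part of a fused or bridged system of two rings, meta to a fused ring and para to a fused ring; in compound 4 it sits on a six-membered aromatic ring of carbon only, para to a large group. It is the same kind of change, not the same one.

In this assay compound 4 is expected to give about 110000 nM, somewhere between 45000 nM and 300000 nM. That expectation means a step that the limit leaves unreadable from compound 3 to compound 4. It rests on the measured step of a 1.2-fold lower number from compound 1 to compound 2 (0.08 log units; within the scatter) and on compound 3 already sitting at the limit of > 100000 nM in this assay, at which 1 of the 3 values shown sits, so a number may again not be reached.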

Compound 4, half-maximal inhibitory concentration: 72500 nM
The estimate for compound 4 lay 1.5-fold (0.18 log units) above the measured number, and the stated range covers the measured number.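

In this assay, the change from phenyl to 4-chlorophenyl gives an at least 1.3-fold lower number from compound 3 to compound 4 (0.13 log units; that floor lies within the scatter), and this is only a floor, since the starting value on this core is a limit rather than a number. Set beside the same change on the core of compound 1, the result fits a change that carries over from one core to the other, but it does not prove that it does: the same change on two cores in this assay, a 1.2-fold lower number (0.08 log units; within the scatter) from compound 1 to compound 2 and an at least 1.3-fold lower number (0.13 log units; that floor lies within the scatter) from compound 3 to compound 4; the limit leaves it open whether they differ The true size of the step on the second core stays unknown, so this pair can neither confirm nor rule out a real gain from the chloro group, and the limit that causes this gap applies to one compound only: the limit of > 100000 nM in this assay, at which 1 of the 4 values shown sits.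

The compounds shown leave open how large the step would be on the second core if its unsubstituted member gave an actual number, and whether the two cores would then agree. They also leave open how a different group in the same place on the phenyl ring, such as a methoxy group, an amine or a carboxylic acid, would read in this assay.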